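Lengthening the Chain: From Compound 2 to Compound 3

This account rests on a few compounds, and the source may have more. Where it says the series, first, only, none or still open, it means among the compounds named here.

Compound 1 `Cc1ncc([N+](=O)[O-])n1CCCCCCBr` gives 69.9 ug/mL in an ADME assay on J774 cells (Mus musculus) for cytotoxicity, read by resazurin assay, with a stated time of 24 h; on this read-out higher numbers stand for weaker inhibition and lower numbers for stronger inhibition. Compound 2 `Cc1ncc([N+](=O)[O-])n1CCCCN1CCCC1` reaches only the assay limit, > 100 ug/mL, in this assay.

Compound 2 thus stands at a limit, not a number. Among the compounds with values here, the one measured step, an at least 1.4-fold higher number from compound 1 to compound 2 (0.15 log units; that floor lies within the scatter), ends at the limit of > 100 ug/mL in this assay, at which 1 of the 2 values shown sits. Compound 3 `Cc1ncc([N+](=O)[O-])n1CCCCCN1CCCC1` differs by (pyrrolidin-1-yl)methyl in place of pyrrolidin-1-yl on a saturated chain carbon, four bonds along the chain from an aromatic nitrogen. Within the data shown here, no measured step covers such a one-carbon lengthening, and the single step available is capped by the limit, so no change beyond the scatter is expected. Compound 3 is estimated at 100 ug/mL, within 50 ug/mL to 200 ug/mL, an expected step of a number no higher from compound 2 to compound 3 (the limit leaves the size open), most likely again reported only as a limit.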

Compound 3, half-maximal inhibitory concentration: > 100 ug/mL
Compound 3 ended at the assay's limit (the forecaster's own chance of this, stated with the estimate: 65%); the middle value sits exactly at the limit.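

Moving the ring one carbon further out, as (pyrrolidin-1-yl)methyl, leaves compound 3 at a limit of the assay, just like compound 2, so the step between them cannot be read. Within the data shown here, the one readable comparison is an at least 1.4-fold higher number from compound 1 to compound 3 (0.15 log units; that floor lies within the scatter), and this floor is no evidence of a real change. The lengthened chain therefore adds a second pyrrolidine compound at the same limit: the limit of > 100 ug/mL in this assay, at which 2 of the 3 values shown sit.

Going by these compounds, whether a longer chain, or a piperidine or morpholine in place of the pyrrolidine ring, would give a true number in this assay remains open.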